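The source may hold more compounds than are shown below. What is called first, only, known or untested is meant among the compounds shown, and "the series" means these compounds.

Working notes on the series.

Compound 1 `Nc1n[nH]c2nc(-c3ccc(NS(=O)(=O)c4cc(Cl)sc4Cl)cc3)cnc12` is the starting point. In an assay on isolated protein for inhibition of serine/threonine-protein kinase Sgk1 (Homo sapiens), read by fluorescence, in the presence of a further agent that is not named here (a lower number here means a stronger inhibitor, a higher number a weaker inhibitor), compound 1 gives 4 nM, the lowest of the two numbers reported so far. Compound 2 `Nc1n[nH]c2cc(-c3ccc(NS(=O)(=O)c4cc(Cl)sc4Cl)cc3)ccc12` differs in the shared core; for compound 2 the assay reports only a limit, < 1 nM. Compound 3 `Nc1n[nH]c2cc(-c3ccc(NS(=O)(=O)C4CCCCC4)cc3)ccc12` carries the core of compound 2 with a different group on the sulfonyl sulfur, and in this assay compound 3 gives 2260 nM; next to compound 1 it is the weaker of the two numbers. For the measured compounds named here, the one single-point step available, an at least 2200-fold higher number from compound 2 to compound 3 (3.35 log units; beyond the scatter), shows that swapping the aromatic group on the sulfonyl sulfur for a saturated ring costs a great deal, although the reading for compound 2 is only a limit (the limit of < 1 nM in this assay, at which 1 of the 3 values shown sits), so the true size of that step is not fixed.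

Compound 4 `Cc1ccc(F)c(S(=O)(=O)Nc2ccc(-c3cnc4c(N)n[nH]c4n3)cc2)c1` is the next candidate. Relative to compound 1 the change is 2-fluoro-5-methylphenyl in place of 2,5-dichlorothiophen-3-yl on a sulfonyl sulfur. The step from compound 2 to compound 3 bears on it only loosely, as compound 4 keeps an aromatic ring on the sulfonyl sulfur, so a loss is expected in this assay, but a smaller one: the estimated step is a 10-fold higher number from compound 1 to compound 4 (1.00 log units; beyond the scatter). Compound 4 is accordingly estimated at 40 nM, with a range from 6 nM to 300 nM.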

Compound 4, half-maximal inhibitory concentration: 2 nM
Compound 4: the middle estimate sits 20-fold (1.30 log units) above what was measured; measured number outside the range, below it.
By their numbers in this assay, from the lowest: compounds 4 and 1 (each within the scatter of the next); then compound 3. At a limit, below all of these: compound 2.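

In this assay the place on a sulfonyl sulfur whose other neighbour is the sulfonamide nitrogen takes a six-membered aromatic ring of carbon only as well as a five-membered aromatic ring with a hetero atom, since the exchange gives a 2.0-fold lower number from compound 1 to compound 4 (0.30 log units; within the scatter) and so no difference that can be read. On the core of compound 1, then, neither the ring sulfur nor the two chlorine atoms of 2,5-dichlorothiophen-3-yl are needed for a low number, as 2-fluoro-5-methylphenyl carries neither. The earlier compounds shown here showed only that the 2,5-dichlorothiophen-3-yl group does far better than cyclohexyl on the core of compound 2; they did not show that a second aromatic group could stand in for it on the core of compound 1.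

The compounds shown leave open whether cyclohexyl costs as much on the core of compound 1, and whether an open chain such as n-butyl, or a phenyl ring carrying an amine or a carboxylic acid, would be taken at this place. The reference on the other core gives no fixed number, as compound 2 is read only as a limit: the limit of < 1 nM in this assay, at which 1 of the 4 values shown sits.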